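A few compounds are considered here, and "the series" means these few. Any claim that something is new, unique, unknown or untested is made for them only; others in the source may bear on it.

Measured so far in a functional assay on P388 cells (Mus musculus) for inhibition; on this read-out lower numbers stand for stronger inhibition and higher numbers for weaker inhibition:
- compound 1 `CN(C)c1ccc(/C=C2\CCCc3ccccc3C2=O)cc1`: 1900 nM
- compound 2 `O=C1CCCCC/C1=C\c1ccc(Cl)cc1`: 19100 nM

Of these two, compound 2 holds the higher number, at 19100 nM. Compound 1 stands at 1900 nM, and that gap lies beyond the usual scatter. For the measured compounds named here, the two compounds differ in more than one place, so the gap cannot be tied to any single change, and no measured step covers a single exchange.

Next is compound 3 `COc1ccc(/C=C2\CCCCCC2=O)cc1`, which carries methoxy in place of chloro on an aromatic carbon, para to a group of 9 heavy atoms: methoxy in place of chloro on an aromatic carbon. Going by the values given here, with no measured precedent for this exchange, the expectation in this assay is no step beyond the scatter, with only a slight lean towards a lower number. Compound 1 at 1900 nM shows that lower numbers occur among these compounds, but it gives no measure of this exchange.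

The estimated step is a 1.5-fold lower number from compound 2 to compound 3 (0.17 log units; within the scatter). For compound 3 the expected value is 13000 nM, with an estimated range of 4500 nM to 38000 nM.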

Compound 3, half-maximal inhibitory concentration: > 50000 nM
Compound 3: no number, only a limit; the forecaster's own chance of this, stated with the estimate: 8%; at least 3.8-fold (0.58 log units) between middle value and limit.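

In this assay compound 3 gives > 50000 nM, which is a limit of the assay and not a number. Methoxy in place of chloro on the aromatic carbon, para to a group of 9 heavy atoms, now supplies the first single-change step in the series, and it runs towards weaker inhibition: an at least 2.6-fold higher number from compound 2 to compound 3 (0.41 log units; beyond the scatter). Only a minimum size can be read from this step, and the true distance between the two compounds stays undefined: the limit of > 50000 nM in this assay, at which 1 of the 3 values shown sits.

From the compounds shown here alone, one exchange at one place gives no general rule for this position, so it remains open how fluoro, nitrile, hydroxy or a carboxylic acid would read there against chloro. Also open, going by these compounds, is whether the loss seen on going from chloro to methoxy would carry over to the core of compound 1, which differs from compound 2 and compound 3 in more than one place and so gives no direct comparison with either.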